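Working notes: from compound 2 to compound 3

The compounds below may be only part of what the source reports. "The series", "measured", "known", "first", "only" and "open" are said of these compounds alone.

Compound 1 `CNC(=O)c1cc(Oc2ccc(C(=O)/C=C/c3ccco3)cc2)ccn1` has no usable result in a functional assay on HepG2 cells (Homo sapiens) for cytotoxicity, read by MTT assay, with a stated time of 72 h (on this read-out lower numbers stand for stronger inhibition and higher numbers for weaker inhibition), where compound 1 is entered as "not determined" (no result reported). Going by the values given here, compound 2 `CNC(=O)c1cc(Oc2ccc(C(=O)/C=C/c3ccc(C#N)cc3)cc2)ccn1` therefore carries the only number, and in this assay compound 2 gives 5430 nM. With nothing to compare it against, compound 2 cannot be ranked and serves only as a reference point.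

The next compound to be read is compound 3 `CNC(=O)c1cc(Oc2ccc(C(=O)/C=C/c3ccc(Cl)cc3Cl)cc2)ccn1`. The change is 2,4-dichlorophenyl in place of 4-cyanophenyl on a double-bonded chain carbon bound to a double-bonded chain carbon, which puts 2,4-dichlorophenyl in place of 4-cyanophenyl on a double-bonded chain carbon bound to a double-bonded chain carbon. The rest of the structure stays the same.

Among the compounds with values here, no step between measured compounds is available to calibrate this exchange, so the expectation is weakly founded. A small move towards stronger inhibition is expected, probably not clearly beyond the usual scatter. The expected size of the move is a 1.4-fold lower number from compound 2 to compound 3 (0.13 log units; within the scatter). The estimate for compound 3 is 4000 nM, with an expected range from 1500 nM to 11000 nM.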

Compound 3, half-maximal inhibitory concentration: 11700 nM
Compound 3: the middle estimate sits 2.9-fold (0.47 log units) below what was measured; measured number outside the range, above it.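

Going by these compounds alone, the exchange can now be sized for the first time: in this assay, 2,4-dichlorophenyl in place of 4-cyanophenyl on a double-bonded chain carbon bound to a double-bonded chain carbon gives a 2.2-fold higher number from compound 2 to compound 3 (0.33 log units; beyond the scatter), a modest weakening beyond the scatter. This position therefore registers a change of substituted phenyl group, and the nitrile-bearing group is the stronger of the two measured here. Nothing available bears on why the number moves in this direction.

As far as these compounds go, a single step cannot separate the loss of the nitrile from the gain of either chlorine, so how an unsubstituted phenyl or a 4-chlorophenyl would read at this place remains open. Within the data shown here, also open is whether a 4-aminophenyl would move the number the other way, and compound 1, at "not determined" (no result reported), offers no second step to help settle this.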